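A Thiophene Swap on a Flat Series

A few compounds are considered here, and "the series" means these few. Any claim that something is new, unique, unknown or untested is made for them only; others in the source may bear on it.

Values in a functional assay on HCT-116 cells (Homo sapiens) for inhibition, read by MTT assay, with a stated time of 48 h (on this read-out higher numbers stand for weaker inhibition and lower numbers for stronger inhibition), so far:
- compound 1 `COc1ccc(-c2cc(-c3cc(OC)c(OC)c(OC)c3)nc(-c3ccccc3)n2)cc1` gives 4780 nM
- compound 2 `COc1cc(-c2cc(-c3ccc(O)cc3O)nc(-c3ccccc3)n2)cc(OC)c1OC` gives 5890 nM
- compound 3 `COc1cc(-c2cc(-c3cccc4ccccc34)nc(-c3ccccc3)n2)cc(OC)c1OC` gives 4930 nM

The number for compound 3 sits second of the three, but that order means little here. The gaps to both neighbours are within the scatter, as a 1.0-fold higher number from compound 1 to compound 3 (0.01 log units; within the scatter) and a 1.2-fold lower number from compound 2 to compound 3 (0.08 log units; within the scatter) show.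

The next molecule, compound 4 `COc1cc(-c2cc(-c3cccs3)nc(-c3ccccc3)n2)cc(OC)c1OC`, keeps the shared core and changes one group: thiophen-2-yl in place of naphthalen-1-yl on an aromatic carbon. Three measured exchanges of this group bear on the change: those two steps and a 1.2-fold higher number from compound 1 to compound 2 (0.09 log units; within the scatter). All three stayed within the scatter, although the groups differ considerably. Within the data shown here, none of the measured compounds carries a thiophen-2-yl group, so the range must stay generous.

No shift beyond the scatter is therefore expected in this assay. The expected step is a 1.0-fold higher number from compound 3 to compound 4 (0.01 log units; within the scatter). For compound 4 the estimated value is 5000 nM, with an expected range from 2400 nM to 10500 nM.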

Compound 4, half-maximal inhibitory concentration: 17000 nM
For compound 4 the middle estimate is 3.4-fold (0.53 log units) below the measured one, outside the stated range (above it).
By their numbers in this assay, from the lowest: compounds 1, 3 and 2 (each within the scatter of the next); then compound 4.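

In this assay this position, until now indifferent among 4-methoxyphenyl, 2,4-dihydroxyphenyl and naphthalen-1-yl, does respond to what it carries: thiophen-2-yl stands apart from all three groups, with a 3.6-fold higher number from compound 1 to compound 4 (0.55 log units; beyond the scatter), a 2.9-fold higher number from compound 2 to compound 4 (0.46 log units; beyond the scatter) and a 3.4-fold higher number from compound 3 to compound 4 (0.54 log units; beyond the scatter). So the wide tolerance suggested by the earlier compounds does not extend to every aromatic group, and the step from compound 3 exchanges two six-membered aromatic rings of carbon only for one five-membered aromatic ring containing sulfur. Nothing in the available data explains why this exchange weakens inhibition.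

The compounds shown leave open whether the weaker number goes with the sulfur, the five-membered ring or the smaller group as a whole. A furan-2-yl or thiophen-3-yl group at this place would help to separate these possibilities.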